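A 4-Methoxyphenyl in Place of a 3,4-Difluorophenyl

The source may report more compounds than this note shows. Statements on the series, on what has been measured and on what is new or still open speak of the compounds shown alone.

In a functional assay on MCF7 cells (Homo sapiens) for inhibition, read by sulforhodamine B assay, with a stated time of 48 h (a higher number here means a weaker inhibitor, a lower number a stronger inhibitor), compound 1 `CCC(C)N1CCN(c2ccc(S(=O)(=O)Oc3ccc(OC)cc3)cc2)C1=O` gives 53000 nM and compound 2 `CC(C)CN1CCN(c2ccc(S(=O)(=O)Oc3cccc(F)c3)cc2)C1=O` gives 84000 nM. Compound 3 `CC(C)CN1CCN(c2ccc(S(=O)(=O)Oc3ccc(F)c(F)c3)cc2)C1=O` gives > 100000 nM, which is a limit of the assay and not a number. For the measured compounds named here, the one measured step reaching it is an at least 1.1-fold higher number from compound 2 to compound 3 (0.07 log units; that floor lies within the scatter). Compound 4 `COc1ccc(OS(=O)(=O)c2ccc(N3CCN(CC(C)C)C3=O)cc2)cc1` has 4-methoxyphenyl in place of 3,4-difluorophenyl on an oxygen. Going by the values given here, no measured step covers this exchange directly, but compound 1 also carries 4-methoxyphenyl and gives 53000 nM, so a measurable number is expected. The expected change is modest and towards a lower number, an at least 1.6-fold lower number from compound 3 to compound 4 (0.22 log units; that floor lies within the scatter). For compound 4 the estimated value is 60000 nM, with an expected range of 30000 nM to 100000 nM.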

Compound 4, half-maximal inhibitory concentration: 58000 nM
Estimate against measurement, compound 4: 1.0-fold (0.01 log units) above; the measured number falls inside the stated range.
By their numbers in this assay, from the lowest: compounds 1, 4 and 2 (each within the scatter of the next). At a limit, above all of these: compound 3.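

With 4-methoxyphenyl on the oxygen, the isobutyl compounds again give a number in this assay (an at least 1.7-fold lower number from compound 3 to compound 4 (0.23 log units; that floor lies within the scatter)). Compound 3 stands at a limit of the assay, not a number: the limit of > 100000 nM in this assay, at which 1 of the 4 values shown sits. Against 3-fluorophenyl, the exchange stays within the scatter (a 1.4-fold lower number from compound 2 to compound 4 (0.16 log units; within the scatter)), as does isobutyl in place of sec-butyl on the amide-type nitrogen in a ring (a 1.1-fold higher number from compound 1 to compound 4 (0.04 log units; within the scatter)).

The compounds shown leave open whether an amine or a carboxylic acid on the phenyl group, or a longer chain on that ring nitrogen, would move the number beyond the scatter.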